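The source may report more compounds than this note shows. Statements on the series, on what has been measured and on what is new or still open speak of the compounds shown alone.

In an ADME assay on the whole organism (plasma) for pharmacokinetics, with Rattus norvegicus as the target, with a stated time of 24 h, at a dose of 10 mg/kg by the oral route (a higher number here means more compound in the circulation at the dose given, a lower number less compound in the circulation), compound 3 `CCc1ccc2c(c1)c(-c1ccc[nH]c1=O)c(C(=O)NS(=O)(=O)C1CC1)n2Cc1cc(F)ccc1F` gives 6140 ng.h/mL and stands within the scatter of compound 1 `Cc1ccc2c(c1)c(-c1ccc[nH]c1=O)c(C(=O)NS(=O)(=O)C1CC1)n2Cc1cc(F)ccc1F` at 4530 ng.h/mL while compound 2 `CCc1ccc2c(c1)c(-c1ccc[nH]c1=O)c(C(=O)NS(=O)(=O)CC)n2Cc1cc(F)ccc1F` reads 2300 ng.h/mL with the gap being a 2.7-fold higher number from compound 2 to compound 3 (0.43 log units; beyond the scatter) for cyclopropyl in place of ethyl on a sulfonyl sulfur. Compound 4 `CC(C)(C)c1ccc2c(c1)c(-c1ccc[nH]c1=O)c(C(=O)NS(=O)(=O)C1CC1)n2Cc1cc(F)ccc1F` differs from compound 3 by tert-butyl in place of ethyl on an aromatic carbon, counted as tert-butyl in place of ethyl on an aromatic carbon and nothing else. Among the compounds with values here, the closest measured change is at that same group, where a 1.4-fold higher number from compound 1 to compound 3 (0.13 log units; within the scatter) is the only evidence, and the sulfonyl step lies elsewhere. Within the data shown here, no tert-butyl compound has been measured, so no step beyond the scatter is expected in this assay here. The estimated change is a 1.2-fold lower number from compound 3 to compound 4 (0.09 log units; within the scatter) with only a weak lean in direction. Compound 4 is estimated at 5000 ng.h/mL with a range from 2000 ng.h/mL to 12000 ng.h/mL as the expected outcome.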

Compound 4, area under the concentration-time curve: 4320 ng.h/mL
Estimate against measurement, compound 4: 1.2-fold (0.06 log units) above, within the range that was stated.
By their numbers in this assay, from the lowest: compounds 2, 4, 1 and 3 (each within the scatter of the next, the first and the last beyond it).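

In this assay tert-butyl in place of ethyl on an aromatic carbon gives a 1.4-fold lower number from compound 3 to compound 4 (0.15 log units; within the scatter) and tert-butyl in place of methyl gives a 1.0-fold lower number from compound 1 to compound 4 (0.02 log units; within the scatter) so the read-out now stays within the scatter across methyl, ethyl and tert-butyl. The earlier compounds shown here had covered only methyl and ethyl at this position, whereas this result extends the range to a group of four carbons. From the compounds shown here alone, what an amine, a carboxylic acid or a longer chain would give at this position remains open. Nothing given here explains why the number holds across these three groups.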